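A few compounds are considered here, and "the series" means these few. Any claim that something is new, unique, unknown or untested is made for them only; others in the source may bear on it.

Measured in an ADME assay on cells (Hepatocyte, Rattus norvegicus, strain Wistar han) for metabolic stability, read by LC-MS, with a stated time of 60 min; a higher number here means faster removal of the compound, a lower number slower removal:

- Compound 1, `CNC(=O)c1cc(C(=O)N[C@H]2CC[C@H](O)CC2)c([C@@H](C)c2cccc(Cl)c2)o1`, gives 1.5 mL/min.
- Compound 2, `CNC(=O)c1cc(C(=O)N[C@H]2CC[C@H](O)CC2)n([C@@H](C)c2ccccc2)n1`, gives 0.9 mL/min.
- Compound 3, `CNC(=O)c1cc(C(=O)N[C@H]2[C@@H]3COC[C@@H]32)c([C@@H](C)c2ccccc2)o1`, returns only a limit, < 0.8 mL/min; this is the limit of < 0.8 mL/min in this assay, at which 1 of the 3 values shown sits, not a number.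

Compound 2 and compound 1 are the two compounds with a numerical result in this assay; compound 2 sits within the scatter of compound 1, so the two are not distinguished by these measurements. Compound 3 sits at the limit of this assay and cannot be ranked against either. Among the compounds with values here, no step between two measured compounds that differ in a single place is available, so there is no measured precedent for a change of the kind now in question.

Compound 4, `CNC(=O)c1cc(C(=O)N[C@H]2CC[C@H](OC)CC2)n([C@@H](C)c2ccccc2)n1`, is the next compound to be run in this assay. It differs from compound 2 in a single place, (methyl in place of hydrogen on an oxygen on a saturated carbon). Within the data shown here, for a change of this size, with no measured step to lean on, the expectation is a step from compound 2 to compound 4 that stays within the scatter, in either direction, as a 1.4-fold higher number from compound 2 to compound 4 (0.16 log units; within the scatter). Compound 4 is accordingly estimated at 1.3 mL/min, with a range from 0.7 mL/min to 2.6 mL/min.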

Compound 4, intrinsic clearance in a liver preparation (reported as CLH), per the amount of preparation that the assay uses: 1.7 mL/min
Beside the measured number, compound 4's estimate is 1.3-fold (0.12 log units) below it; low and high end bracket the measured number.
By their numbers in this assay, from the lowest: compounds 2, 1 and 4 (each within the scatter of the next). At a limit, below all of these: compound 3.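

In this assay the series now has its first measured step at a single place, hydroxy to methoxy, or 4-hydroxycyclohexyl to 4-methoxycyclohexyl: a 1.9-fold higher number from compound 2 to compound 4 (0.28 log units; within the scatter). This step shows that, with the core of compound 2, methyl in place of hydrogen on this oxygen gives a result that cannot be told apart from the parent, so the free hydroxy is not required to keep the number in this range; as a single step on a single core, it sets no pattern for the series. Nothing among the data shown gives a reason for the size of this step.

Still open, as far as these compounds go, is whether an ethyl group or a longer chain on this oxygen, or an amine or a carboxylic acid in place of the hydroxy, would also stay within the scatter of compound 2. Equally open, from the compounds shown here alone, is whether hydroxy to methoxy reads the same way on the core of compound 1, which carries the same 4-hydroxycyclohexyl group but has no measured partner of this kind.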